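Chloro for methoxy across two cores at the alpha-1D receptor

The source may report more compounds than this note shows. Statements on the series, on what has been measured and on what is new or still open speak of the compounds shown alone.

Compound 2 `COc1ccccc1C1CCc2nc[nH]c2C1` gives 3500 nM in a functional assay on CHO cells for agonist activity at Alpha-1D adrenergic receptor (Homo sapiens), read by FLIPR and calcium flux; a lower number here means that less compound is needed, a higher number that more compound is needed for the effect. Compound 1 `Clc1ccccc1C1CCc2nc[nH]c2C1` returns only a limit of this assay, > 10000 nM. The step of an at least 2.8-fold higher number from compound 2 to compound 1 (0.45 log units; beyond the scatter) is the change (chloro in place of methoxy on an aromatic carbon); its size is known only as a lower bound because one value sits at the limit of > 10000 nM in this assay, at which 1 of the 3 values shown sits.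

Compound 3 `COc1ccccc1C1Cc2nccn2C1` carries a different core, and the difference between the two cores is not broken down here; in this assay compound 3 has "not determined" (no result reported). Compound 4 `Clc1ccccc1C1Cc2nccn2C1` is made from compound 3 by chloro in place of methoxy on an aromatic carbon. The surroundings are not identical: in compound 2 the place is ortho to a group of 9 heavy atoms, in compound 3 ortho to a group of 8 heavy atoms, so this is the same kind of change rather than the same change.

Within the data shown here, with no number for compound 3, the expectation rests on the one measured step alone: the loss seen in an at least 2.8-fold higher number from compound 2 to compound 1 (0.45 log units; beyond the scatter) is expected to repeat in this assay, and compound 4 is therefore expected to sit near or at the limit, estimated at 15000 nM (range 3000 nM to 60000 nM).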

Compound 4, half-maximal effective concentration: 364 nM
Estimate against measurement, compound 4: 41-fold (1.61 log units) above, outside the stated range (below it).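

In this assay, among these compounds, compound 4 gives 364 nM and compound 3 has "not determined" (no result reported), so no step between them can be read. Left open is whether chloro in place of methoxy on an aromatic carbon shifts the number in the same direction on the core of compound 3 as on the core of compound 2.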